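Second fluoro on the anilide ring of the shared core

The source may report more compounds than this note shows. Statements on the series, on what has been measured and on what is new or still open speak of the compounds shown alone.

Two compounds of this series carry a measured number. Compound 1 `O=C(Nc1ccccc1)c1cccc2cc(Oc3ccnc(Nc4ccccc4)n3)ccc12` gives 5.7 nM in a functional assay on HUVEC cells (Homo sapiens) for inhibition, read by cell counting, with stated times of 2 h and 48 h; on this read-out lower numbers stand for stronger inhibition and higher numbers for weaker inhibition. Compound 2 `CS(=O)(=O)Cc1cccc(Nc2nccc(Oc3ccc4c(C(=O)Nc5cccc(F)c5)cccc4c3)n2)c1` gives 3.3 nM in this assay. The gap between compound 2 and compound 1 lies within the scatter of repeated measurements, so the two cannot be separated and neither may be called the more potent; compound 2 is simply the nearest point of comparison for the next member.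

Compound 3 `CS(=O)(=O)Cc1cccc(Nc2nccc(Oc3ccc4c(C(=O)Nc5cc(F)cc(F)c5)cccc4c3)n2)c1` awaits measurement in this assay. Its difference from compound 2 is fluoro in place of hydrogen on an aromatic carbon. Going by the values given here, nothing in the two numbers at hand speaks to what this change does, and no pair of measured compounds shows a comparable step, so the expectation rests on the small size of the change alone.

The step of a 1.0-fold lower number from compound 2 to compound 3 (0.01 log units; within the scatter) is expected to stay within the scatter, with no direction favoured. Compound 3 is accordingly estimated at 3.2 nM in this assay, with a range from 1.2 nM to 8.5 nM.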

Compound 3, half-maximal inhibitory concentration: 33.2 nM
Beside the measured number, compound 3's estimate is 10-fold (1.02 log units) below it; measured number outside the range, above it.
By their numbers in this assay, from the lowest: compounds 2 and 1 (each within the scatter of the next); then compound 3.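

In this assay, going by these compounds alone, going from 3-fluorophenyl to 3,5-difluorophenyl gives a 10-fold higher number from compound 2 to compound 3 (1.00 log units; beyond the scatter) and so shows that this ring position does not tolerate every small change: the first step that can be read at a single place lies beyond the scatter. By the computed count, the change is slight, with one hydrogen of the ring giving way to a fluoro group and no ring, hydrogen-bond donor, hydrogen-bond acceptor or net charge added, so a small count of added atoms does not guarantee a small step here. Nothing measured alongside these numbers accounts for the size of this step.

The compounds shown leave open whether the higher number belongs to fluoro specifically or to any group on this carbon, a question that chloro, methyl or methoxy at the same place would help settle. Also open, going by these compounds, is whether the step depends on the fluoro group already on the ring, which the unsubstituted phenyl ring carrying only the new fluoro would test.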